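The source may report more compounds than this note shows. Statements on the series, on what has been measured and on what is new or still open speak of the compounds shown alone.

Compound 1 `O=c1ccoc2cc(OCc3cn(Cc4ccc(F)cc4)nn3)ccc12` is the reference here. In a functional assay on QGY7701 cells (Homo sapiens) for cytotoxicity, read by MTT assay, with a stated time of 48 h (a higher number here means a weaker inhibitor, a lower number a stronger inhibitor), compound 1 gives 14400 nM, the lowest of the two numbers recorded. Its nearest neighbour is compound 3 `C#CCOc1ccc2c(=O)ccoc2c1`, which in this assay gives 58500 nM. Compound 2 `CC(C)(C)c1ccc(Cn2cc(COc3ccc4c(=O)ccoc4c3)nn2)cc1` gives only a limit in this assay, > 100000 nM. Within the data shown here, the single measured step that bears on the new compound is an at least 6.9-fold higher number from compound 1 to compound 2 (0.84 log units; beyond the scatter), a change of the group on the benzyl ring that sits on the triazole.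

Compound 4 `N#Cc1cccc(Cn2cc(COc3ccc4c(=O)ccoc4c3)nn2)c1` differs from compound 1 as follows: 3-cyanophenyl in place of 4-fluorophenyl on a saturated chain carbon bound to an aromatic nitrogen. Among the measured compounds shown here, only one step on this ring is known, and it ran toward a weaker number ending at the limit of > 100000 nM in this assay, at which 1 of the 3 values shown sits. On that basis a step of a 1.7-fold higher number from compound 1 to compound 4 (0.24 log units; within the scatter) is expected, a modest weakening. Compound 4 is therefore estimated at 25000 nM, between 8000 nM and 80000 nM.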

Compound 4, half-maximal inhibitory concentration: 24400 nM
For compound 4 the middle estimate is 1.0-fold (0.01 log units) above the measured one, and the stated range covers the measured number.
By their numbers in this assay, from the lowest: compounds 1 and 4 (each within the scatter of the next); then compound 3. At a limit, above all of these: compound 2.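

In this assay, 3-cyanobenzyl in place of 4-fluorobenzyl gives a 1.7-fold higher number from compound 1 to compound 4 (0.23 log units; within the scatter). The benzyl ring on the triazole can therefore carry a nitrile with no change beyond the scatter, whereas tert-butyl in place of fluoro gave an at least 6.9-fold higher number from compound 1 to compound 2 (0.84 log units; beyond the scatter). The value of compound 2 remains a limit: the limit of > 100000 nM in this assay, at which 1 of the 4 values shown sits.

The step to compound 4 changes both the group and its place on the ring, and the compounds shown cannot separate the two. As far as these compounds go, how an amine or a carboxylic acid on this ring would read remains open.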